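Swapping Fluoro for Chloro in Two Cytotoxicity Pairs

The source may hold more compounds than are shown below. What is called first, only, known or untested is meant among the compounds shown, and "the series" means these compounds.

Four compounds sharing a core are compared in an ADME assay on Huh-7 cells (Homo sapiens) for cytotoxicity, with a stated time of 3 days; on this read-out lower numbers stand for higher toxicity in this test and higher numbers for lower toxicity in this test. Compound 1 `O=C(NC1CC1)c1c(NO)cc(-c2ccc(F)cc2)oc1=O` gives only a limit of the assay, > 20000 nM. Compound 2 `O=C(NC1CC1)c1c(NO)cc(-c2ccc(Cl)cc2)oc1=O` gives 12800 nM. The change from compound 1 to compound 2 is chloro in place of fluoro on an aromatic carbon, and it produced an at least 1.5-fold lower number from compound 1 to compound 2 (0.19 log units; that floor lies within the scatter), a step that starts from a limit because the limit of > 20000 nM in this assay, at which 2 of the 3 values shown sit, applies to compound 1.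

Compound 3 `O=C(Nc1ccc(F)cc1)c1c(NCCO)cc(-c2cccc(Br)c2)oc1=O` likewise gives only a limit, > 20000 nM. How the core of compound 3 differs from the core of compound 1 is not broken down here. Compound 4 `O=C(Nc1ccc(Cl)cc1)c1c(NCCO)cc(-c2cccc(Br)c2)oc1=O` has not been measured; it differs from compound 3 by chloro in place of fluoro on an aromatic carbon, the same change as from compound 1 to compound 2. The expected step is a number no higher from compound 3 to compound 4 (the limit leaves the size open), resting on an at least 1.5-fold lower number from compound 1 to compound 2 (0.19 log units; that floor lies within the scatter). Compound 4 is therefore estimated at 20000 nM.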

Compound 4, half-maximal cytotoxic concentration: 17000 nM
For compound 4 the middle estimate is 1.2-fold (0.07 log units) above the measured one; the range from low to high includes it.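

Chloro in place of fluoro in this assay gives an at least 1.1-fold lower number from compound 3 to compound 4 (0.07 log units; that floor lies within the scatter). Compound 3 gives only a limit of the assay, > 20000 nM, so this step, like the earlier one on the other core, has a floor but no true size. The two pairs read in the same direction, but this shows neither that the change has the same size on both cores nor that it moves the number beyond the scatter on either: the same change on two cores in this assay, an at least 1.5-fold lower number (0.19 log units; that floor lies within the scatter) from compound 1 to compound 2 and an at least 1.1-fold lower number (0.07 log units; that floor lies within the scatter) from compound 3 to compound 4; the limit leaves it open whether they differ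

The compounds shown leave open how the step would read on a pair whose fluoro member gives a true number rather than a limit. They also leave open what a methyl group or a nitrile in that place would do on either core.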